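The source may report more compounds than this note shows. Statements on the series, on what has been measured and on what is new or still open speak of the compounds shown alone.

Three thiourea-type compounds have been measured in an assay for inhibition of epoxide hydrolase 1 (Homo sapiens), read by fluorescence, using microsomes; on this read-out higher numbers stand for weaker inhibition and lower numbers for stronger inhibition. Compound 3 `O=C(NC(=S)Nc1ccc(Cl)cc1)c1ccccc1` gives 1640 nM and compound 2 `CC(=O)NC(=S)Nc1ccc(Cl)cc1` gives 2210 nM; the change between them, (methyl in place of phenyl on a carbonyl carbon), gave a 1.3-fold higher number from compound 3 to compound 2 (0.13 log units; within the scatter). Compound 1 `O=C(NC(=S)Nc1ccc(Br)c(C(F)(F)F)c1)c1ccccc1` gives 1170 nM, and how its core differs from that of compound 3 is not broken down here. The unmeasured compound 4 `CC(=O)NC(=S)Nc1ccc(Br)c(C(F)(F)F)c1` is related to compound 1 by the same change, (methyl in place of phenyl on a carbonyl carbon), made on the same carbonyl carbon. Since that change between compound 3 and compound 2 moved the number only within the scatter, the step from compound 1 to compound 4 in this assay is expected to be of similar size, namely a 1.3-fold higher number from compound 1 to compound 4 (0.11 log units; within the scatter). On that basis compound 4 is estimated at 1500 nM, with a likely range from 800 nM to 3000 nM.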

Compound 4, half-maximal inhibitory concentration: 1390 nM
Compound 4: the middle estimate sits 1.1-fold (0.03 log units) above what was measured, and the stated range covers the measured number.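

In this assay, putting methyl in place of phenyl on the carbonyl carbon gave a 1.2-fold higher number from compound 1 to compound 4 (0.07 log units; within the scatter). Set beside the earlier case, the change carries from one core to the other with no difference that can be told apart: the same change on two cores in this assay, a 1.3-fold higher number (0.13 log units; within the scatter) from compound 3 to compound 2 and a 1.2-fold higher number (0.07 log units; within the scatter) from compound 1 to compound 4, 1.1-fold (0.05 log units) apart, within the scatter of two such steps. This shows that the swap left the number within the scatter on both of these cores, but it does not show that the same would hold on any other core, and with steps this small the agreement is a weak test of transferability.

The compounds shown leave open how a longer chain, an amine or a carboxylic acid-bearing group on that carbonyl carbon would read in this assay. They also leave open whether any such group would move the number beyond the scatter.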